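Urea series: pyridyl attachment point and microsomal clearance

A few compounds are considered here, and "the series" means these few. Any claim that something is new, unique, unknown or untested is made for them only; others in the source may bear on it.

The set holds three measured diaryl ureas and one awaiting data. Compound 1 `O=C(Nc1ccc(C(=O)O)cc1)Nc1ccc(F)c(C(F)(F)F)c1`, compound 2 `O=C(Nc1ccnc(C(F)(F)F)c1)Nc1ccnc(C(F)(F)F)c1` and compound 3 `O=C(Nc1ccc(F)c(C(F)(F)F)c1)Nc1ccccn1` have been run in an ADME assay on microsomes from liver (Homo sapiens) for metabolic stability, using NADPH, with a stated time of 60 min; a higher number here means faster removal of the compound, a lower number slower removal. Compound 1 returns only a limit of the assay, < 7 uL/min. Compound 2 likewise returns only a limit, < 7 uL/min. Within the data shown here, compound 3 is the sole member with a number, giving 188 uL/min in this assay, so it stands as the one measured value in the set. Compound 1 and compound 2 each sit at the assay limit; (the limit of < 7 uL/min in this assay, at which 2 of the 3 values shown sit).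

Compound 4 `O=C(Nc1ccncc1)Nc1ccc(F)c(C(F)(F)F)c1` is not yet measured. It differs from compound 3 in one place: pyridin-4-yl in place of pyridin-2-yl on an amide-type nitrogen. Among the measured compounds shown here, no measured pair in the set differs at this position, so the size of the step is open. Compound 2, which carries pyridin-4-yl groups, gives only the limit < 7 uL/min. On that basis compound 4 is expected to show slower removal than compound 3, the expected step being a 3.1-fold lower number from compound 3 to compound 4 (0.50 log units; beyond the scatter) in this assay. The estimate for compound 4 is 60 uL/min, with a range from 15 uL/min to 150 uL/min.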

Compound 4, intrinsic clearance in a liver preparation (reported as CLH), per the amount of preparation that the assay uses in the Homo sapiens assay: 12 uL/min
Compound 4: the middle estimate sits 5.0-fold (0.70 log units) above what was measured; measured number below the stated range.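

Attachment point alone carries a large effect at this position: with the same atoms and the same counts on both sides, the change from pyridin-2-yl to pyridin-4-yl on the amide-type nitrogen gives, in the Homo sapiens assay, a 16-fold lower number from compound 3 to compound 4 (1.19 log units; beyond the scatter). In a physicochemical assay for solubility, read by nephelometry, measured as kinetic solubility, at pH 2 (on this read-out lower numbers stand for lower solubility and higher numbers for higher solubility), compound 3 gives 1.6 ug/mL and compound 4 gives 6.3 ug/mL. The step in the physicochemical assay is a 3.9-fold higher number from compound 3 to compound 4 (0.60 log units; beyond the scatter), so in this one pair slower removal and higher solubility arrive together.

On these data alone, this rests on a single pair, so whether the step holds with a different group on the other side of the urea stays open. Also open, as far as these compounds go, is how a plain phenyl ring, or a pyridin-4-yl ring carrying a methoxy group or an amine, would read in both assays.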